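The source may hold more compounds than are shown below. What is called first, only, known or untested is meant among the compounds shown, and "the series" means these compounds.

Compound 1 `Cc1cnn(C(=O)N2CCCCC2)c1` is measured in an assay on membranes from brain for binding affinity to neutral cholesterol ester hydrolase 1 (Mus musculus), read by fluorescence, with stated times of 1 h and 30 min (a higher number here means a weaker inhibitor, a lower number a stronger inhibitor), and gives > 100000 nM, which is a limit of the assay. Compound 2 `O=C(N1CCCCC1)n1cccn1` gives in this assay > 100000 nM, again a limit. Compound 3 `Cc1cnn(C(=O)N(C)CCN(C)Cc2ccc(OCc3ccccc3)cc2)c1` gives in this assay > 100000 nM, also a limit.

Compound 3 therefore stands where every other compound stands: at the limit of > 100000 nM in this assay, at which 3 of the 3 values shown sit, with no number read for any of them. Among the measured compounds shown here, the one step between measured compounds, a step that the two limits leave unreadable from compound 1 to compound 2, which replaces a methyl with a hydrogen on an aromatic carbon, stays unreadable for the same reason.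

Compound 4 `CN(CCN(C)C(=O)n1cc(C#N)cn1)Cc1ccc(OCc2ccccc2)cc1` differs from compound 3 in one place: cyano in place of methyl on an aromatic carbon. For the measured compounds named here, no measured step bears readably on this change, since the only step available gives no size. The expectation for compound 4 therefore rests on the limit alone, and the expected step of an at least 1.6-fold lower number from compound 3 to compound 4 (0.22 log units; that floor lies within the scatter) is not anchored by any measured number. Compound 4 is estimated at 60000 nM, within 3000 nM to 200000 nM, with a good chance that this assay once more reports only a limit.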

Compound 4, half-maximal inhibitory concentration: > 100000 nM
Compound 4 was reported as a limit; the forecaster's own chance of this, stated with the estimate: 60%; middle value at least 1.6-fold (0.22 log units) from the limit.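

The change from compound 3 to compound 4 gives no readable step, as both results are limits and not numbers: the limit of > 100000 nM in this assay, at which 4 of the 4 values shown sit.

The compounds shown leave open whether cyano in place of methyl changes inhibition at all, and whether any close relative gives a real number in this assay.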